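The source may report more compounds than this note shows. Statements on the series, on what has been measured and on what is new or still open speak of the compounds shown alone.

The measured compounds: compound 1 `O=C(Nc1ccccc1O)c1cccc(N2C(=O)c3ccccc3C2=O)c1`, 77 nM; compound 2 `O=C(Nc1cccc(Cl)c1)c1cccc(N2C(=O)c3ccccc3C2=O)c1`, 1780 nM; compound 3 `O=C(Nc1ccccn1)c1cccc(N2C(=O)c3ccccc3C2=O)c1`, 1260 nM.

In an in vitro functional assay on HEK293-A cells for antagonist activity at metabotropic glutamate receptor 5 (Rattus norvegicus), read by calcium flux (a lower number here means a stronger inhibitor, a higher number a weaker inhibitor), compound 3 stands second highest of the three numbers. Its nearest neighbour is compound 2, and the step of a 1.4-fold lower number from compound 2 to compound 3 (0.15 log units; within the scatter) lies within the scatter. Its furthest is compound 1, and the step of a 16-fold higher number from compound 1 to compound 3 (1.21 log units; beyond the scatter) is large. Compound 4 `O=C(Nc1ccccc1F)c1cccc(N2C(=O)c3ccccc3C2=O)c1` has not been measured; it differs from compound 3 by 2-fluorophenyl in place of pyridin-2-yl on an amide-type nitrogen.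

For the measured compounds named here, no measured step swaps pyridin-2-yl for 2-fluorophenyl, so the bearing of the measured steps is indirect. The step of a 23-fold higher number from compound 1 to compound 2 (1.36 log units; beyond the scatter) shows that a plain halogen-bearing phenyl on this nitrogen sits far above compound 1, while a 1.4-fold lower number from compound 2 to compound 3 (0.15 log units; within the scatter) shows halogen-bearing phenyl and pyridin-2-yl within the scatter of each other. Compound 4 carries a halogen-bearing phenyl, so compound 4 is expected near compound 3, with a 1.8-fold lower number from compound 3 to compound 4 (0.26 log units; within the scatter) as a modest step toward a lower number. The estimate for compound 4 is 700 nM, within 200 nM to 2500 nM.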

Compound 4, half-maximal inhibitory concentration: 1050 nM
Compound 4: middle estimate off by 1.5-fold (0.18 log units), on the low side; measured number inside the range.
By their numbers in this assay, from the lowest: compound 1; then compounds 4, 3 and 2 (each within the scatter of the next).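

In this assay, the steps of a 1.2-fold lower number from compound 3 to compound 4 (0.08 log units; within the scatter) and a 1.7-fold lower number from compound 2 to compound 4 (0.23 log units; within the scatter) both lie within the scatter, so 2-fluorophenyl on the amide-type nitrogen cannot be told apart from pyridin-2-yl or 3-chlorophenyl. For the compounds shown here, the step of a 14-fold higher number from compound 1 to compound 4 (1.13 log units; beyond the scatter) is large and is the first to exchange only one group on an aromatic carbon, fluoro in place of hydroxy, so the gap to compound 1 is seen for a single substituent rather than for a change of the whole ring or of the group's place on it. Nothing measured here accounts for the gap between hydroxy and fluoro.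

Still open, from the compounds shown here alone, is whether a methoxy or an amino group on that aromatic carbon would stand with compound 1 or with compound 4. Also open, going by these compounds, is what a hydroxy on another carbon of the phenyl ring would give.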